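Nitro for chloro on the aryl of a sugar-linked oxadiazole

The compounds below may be only part of what the source reports. "The series", "measured", "known", "first", "only" and "open" are said of these compounds alone.

Measured compounds:
compound 1 `COc1cc(-c2cc(CO[C@@H]3O[C@H](CSc4ncn[nH]4)[C@H]4OC5(CCCC5)O[C@@H]34)on2)cc(OC)c1OC` — 87000 nM
compound 2 `Nc1nnc(SC[C@H]2O[C@@H](OCc3noc(-c4ccc(Cl)cc4)n3)[C@@H]3OC4(CCCC4)O[C@@H]32)s1` — 30000 nM
compound 3 `CC1(C)O[C@H]2[C@H](OCc3noc(-c4ccc([N+](=O)[O-])cc4)n3)O[C@H](CSc3ncn[nH]3)[C@H]2O1` — > 100000 nM

In a functional assay on HBL-100 cells (Homo sapiens) for antiproliferative activity, read by sulforhodamine B assay, with a stated time of 48 h (on this read-out lower numbers stand for stronger inhibition of growth and higher numbers for weaker inhibition of growth), compound 2 gives 30000 nM, the lower of the two numbers in hand; the nearest is compound 1, which sits higher by an amount beyond the usual scatter. Compound 3 gives only a limit in this assay, > 100000 nM, and not a number; that limit is recorded as the limit of > 100000 nM in this assay, at which 1 of the 3 values shown sits. Compound 3 and compound 4 are not a single-change pair, so their values are simply noted side by side.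

Compound 4 `Nc1nnc(SC[C@H]2O[C@@H](OCc3noc(-c4ccc([N+](=O)[O-])cc4)n3)[C@@H]3OC4(CCCC4)O[C@@H]32)s1` differs from compound 2 by one change: nitro in place of chloro on an aromatic carbon. Going by the values given here, no measured step of this kind exists in the set. The expected step is a 2.0-fold higher number from compound 2 to compound 4 (0.30 log units; within the scatter), toward weaker inhibition of growth, with a fair chance that only a limit is returned. Compound 4 is estimated at 60000 nM, within a range from 20000 nM to 150000 nM.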

Compound 4, concentration for 50% growth inhibition: 26000 nM
Compound 4: middle estimate off by 2.3-fold (0.36 log units), on the high side, and the stated range covers the measured number.
By their numbers in this assay, from the lowest: compounds 4 and 2 (each within the scatter of the next); then compound 1. At a limit, above all of these: compound 3.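

In this assay, the series now has its first pair differing in one place, 4-chlorophenyl to 4-nitrophenyl, and a 1.2-fold lower number from compound 2 to compound 4 (0.06 log units; within the scatter) leaves the two compounds inseparable. On this aromatic carbon, para to a large group, nitro with its 3 heavy atoms and 2 hydrogen-bond acceptors gives a number within the scatter of the one for chloro, with 1 heavy atom and no hydrogen-bond acceptors. Nothing measured here accounts for this equivalence.

A single pair cannot show whether the position accepts substituents generally, and an amine or a carboxylic acid on this carbon could read differently. Also open, on these data alone, is whether nitro and chloro read alike on the core of compound 3, whose value is a limit.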